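The source may hold more compounds than are shown below. What is called first, only, known or untested is meant among the compounds shown, and "the series" means these compounds.

The values measured so far in a functional assay on OPM-2 cells (Homo sapiens) for inhibition, with a stated time of 24 h, in the presence of a further agent that is not named here (on this read-out lower numbers stand for stronger inhibition and higher numbers for weaker inhibition), are these
compound 1 (`CO[C@@]1(CC(=O)N(C)C)/C=C/C[C@H](C)[C@@H](C)S(=O)(=O)NC(=O)c2ccc3c(c2)N(C[C@@H]2CC[C@H]21)C[C@@]1(CCCc2cc(Cl)ccc21)CO3`) gives 41 nM
compound 2 (`CO[C@H]1/C=C/C[C@H](C)[C@@H](C)S(=O)(=O)NC(=O)c2ccc3c(c2)N(C[C@@H]2CC[C@H]21)C[C@@]1(CCCc2cc(Cl)ccc21)CO3`) gives 240 nM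
compound 3 (`C[C@@H]1[C@@H](C)CCC[C@H](C2OCC(N(C)C)CO2)[C@@H]2CC[C@H]2CN2C[C@@]3(CCCc4cc(Cl)ccc43)COc3ccc(cc32)C(=O)NS1(=O)=O`) gives 19 nM

Of these three, compound 2 has the highest number, and its 240 nM lies beyond the scatter from both of the others. It is therefore the weakest inhibitor of the set. Compound 4 (`C[C@@H]1[C@@H](C)C/C=C/[C@H](OCC(=O)O)[C@@H]2CC[C@H]2CN2C[C@@]3(CCCc4cc(Cl)ccc43)COc3ccc(cc32)C(=O)NS1(=O)=O`) has not yet been measured. Its change from compound 2 is carboxy in place of hydrogen on a saturated chain carbon bound to an oxygen on a saturated carbon. The same difference can also be read as methoxy to carboxymethoxy. For the measured compounds named here, no measured pair shows this change directly, so its size cannot be read from the data. Compound 1 at 41 nM and compound 3 at 19 nM both lie lower than compound 2, which gives only weak support for expecting a lower number. In this assay the expectation is therefore a small fall that stays within the scatter, though a larger move in either direction remains possible. The expected step is a 1.6-fold lower number from compound 2 to compound 4 (0.20 log units; within the scatter), and this estimate is uncertain. For compound 4 the estimated value is 150 nM, with an expected range from 40 nM to 600 nM.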

Compound 4, half-maximal inhibitory concentration: 1100 nM
Compound 4: middle estimate off by 7.3-fold (0.87 log units), on the low side; the whole stated range lies below it.
By their numbers in this assay, from the lowest: compound 3; then compound 1; then compound 2; then compound 4.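

Carboxy in place of hydrogen on a saturated chain carbon bound to an oxygen on a saturated carbon brings a 4.6-fold higher number from compound 2 to compound 4 (0.66 log units; beyond the scatter) in this assay, and this is the first direct reading of any change at this position. The earlier compounds shown here differ from one another in more than one place, so they could not show the direction of this change; here the methoxy to carboxymethoxy exchange clearly weakens inhibition, on a scaffold that otherwise stays the same. Nothing given here accounts for this loss of inhibition.

From the compounds shown here alone, what stays open is whether the loss belongs to the carboxylic acid itself or to any extension of the methoxy group, a question that a methyl ester, a primary amide, an amine or a plain ethoxy group at the same oxygen would address. Going by these compounds, it also remains open whether a longer chain ending in a carboxylic acid would behave the same way, and whether this single step would carry over to the compounds that bear other groups at this position.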